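Swapping the aryl group on the shared core

This account rests on a few compounds, and the source may have more. Where it says the series, first, only, none or still open, it means among the compounds named here.

Compound 1 `Cc1nc(-c2ccsc2)sc1COc1ccc2c(c1)OCC2CC(=O)O` gives 68.5 nM in a functional assay on CHO cells for agonist activity at Free fatty acid receptor 1 (Homo sapiens), read by FLIPR and calcium flux; a higher number here means that more compound is needed for the effect, a lower number that less compound is needed. Compound 2 `Cc1nc(-c2cccc(C(F)(F)F)c2)sc1COc1ccc2c(c1)OCC2CC(=O)O` stands without a single number: in this assay compound 2 gives "not determined" (no result reported). Compound 3 `COc1ccc(-c2nc(C)c(COc3ccc4c(c3)OCC4CC(=O)O)s2)cc1` differs from compound 2 by 4-methoxyphenyl in place of 3-(trifluoromethyl)phenyl on an aromatic carbon. Within the data shown here, no measured step links compound 2 and compound 3, so the data offer no direction for this change and no size beyond the scatter; the only measured anchor on this core is compound 1. Compound 3 is therefore expected to give roughly 110 nM in this assay, with a plausible range from 25 nM to 500 nM.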

Compound 3, half-maximal effective concentration: 123 nM
For compound 3 the middle estimate is 1.1-fold (0.05 log units) below the measured one; the measured number falls inside the stated range.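

In this assay the move from thiophen-3-yl to 4-methoxyphenyl on this aromatic carbon gives a 1.8-fold higher number from compound 1 to compound 3 (0.25 log units; within the scatter), so the two groups cannot be told apart here. Among these compounds, this gives the first readable step at this position and shows that a five-membered and a six-membered aromatic ring can both stand there with no change beyond the scatter. Compound 2 has no number, so steps to it cannot be read, and nothing available explains the result.

As far as these compounds go, it remains open how a plain phenyl, a pyridine ring or an amine such as piperidine would read on this carbon.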